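Ring Size of the Amine Substituent and Lipase Inhibition

The source may hold more compounds than are shown below. What is called first, only, known or untested is meant among the compounds shown, and "the series" means these compounds.

Compound 1, `O=C(Oc1nsnc1N1CCCC1)N1CCCCC1`: 496 nM
Compound 2, `O=C(Oc1nsnc1N1CCCCC1)N1CCCCC1`: 152 nM

Both compounds were tested in an assay on isolated protein for inhibition of lysosomal acid lipase/cholesteryl ester hydrolase (Homo sapiens), read by fluorescence, with a stated time of 30 min; a lower number here means a stronger inhibitor, a higher number a weaker inhibitor. Within the data shown here, compound 2 holds the lowest of the two numbers, and the only measured step, a 3.3-fold lower number from compound 1 to compound 2 (0.51 log units; beyond the scatter), came from piperidin-1-yl in place of pyrrolidin-1-yl on the aromatic carbon. Compound 3, `O=C(Oc1nsnc1N1CCCCCC1)N1CCCCC1`, continues this change: azepan-1-yl in place of piperidin-1-yl on an aromatic carbon. That same step bears on it, because a 3.3-fold lower number from compound 1 to compound 2 (0.51 log units; beyond the scatter) already accompanied one ring enlargement, so a further enlargement is expected to bring a smaller step, a 1.5-fold lower number from compound 2 to compound 3 (0.18 log units; within the scatter). Compound 3 is therefore estimated at 100 nM, within 40 nM to 300 nM.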

Compound 3, half-maximal inhibitory concentration: 300 nM
The estimate for compound 3 lay 3.0-fold (0.48 log units) below the measured number, within the range that was stated.
By their numbers in this assay, from the lowest: compounds 2, 3 and 1 (each within the scatter of the next, the first and the last beyond it).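

Replacing piperidin-1-yl with azepan-1-yl on this aromatic carbon gives a 2.0-fold higher number from compound 2 to compound 3 (0.30 log units; within the scatter) and replacing pyrrolidin-1-yl with azepan-1-yl gives a 1.7-fold lower number from compound 1 to compound 3 (0.22 log units; within the scatter), so the seven-membered ring cannot be told apart from either smaller ring. The step of a 3.3-fold lower number from compound 1 to compound 2 (0.51 log units; beyond the scatter) therefore does not carry on to a further enlargement, and compound 3 goes against any reading in which a larger ring means a lower number. Nothing at hand accounts for this result.

Going by these compounds, whether a morpholin-4-yl ring or an open-chain diethylamino group at this place would match compound 2 remains open.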